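The source may report more compounds than this note shows. Statements on the series, on what has been measured and on what is new or still open speak of the compounds shown alone.

Compound 1 `C=CCOn1c(-c2cccc(C#N)c2)nc(C)c1C(=O)OCC`: 5860 nM
Compound 2 `CCOC(=O)c1c(C)nc(-c2cccc(C#N)c2)n1OCc1ccc(Br)cc1`: 24600 nM

In a functional assay on a cell-free system (plasma, Oryctolagus cuniculus) for inhibition, with stated times of 5 min, 1 min and 6 min (a lower number here means a stronger inhibitor, a higher number a weaker inhibitor), compound 2 gives 24600 nM, the higher of the two numbers. Compound 3 `CCOC(=O)c1c(C)nc(-c2cccc(C#N)c2)n1OCc1ccc(C(=O)OC)cc1` differs from it by methoxycarbonyl in place of bromo on an aromatic carbon, para to a large group. Among the compounds with values here, the only measured step, a 4.2-fold higher number from compound 1 to compound 2 (0.62 log units; beyond the scatter), is modest and replaces vinyl with 4-bromophenyl. Within the data shown here, no measured step replaces the bromo itself, so the data give no direction for this change. The expected result is a 1.2-fold lower number from compound 2 to compound 3 (0.09 log units; within the scatter), with no move beyond the scatter in this assay. The estimate for compound 3 is 20000 nM, with an expected range of 7000 nM to 60000 nM.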

Compound 3, half-maximal inhibitory concentration: 9470 nM
Beside the measured number, compound 3's estimate is 2.1-fold (0.32 log units) above it; measured number inside the range.
By their numbers in this assay, from the lowest: compounds 1 and 3 (each within the scatter of the next); then compound 2.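

In this assay, within the data shown here, the group on this aromatic carbon, para to a large group, changes the result: the step is a 2.6-fold lower number from compound 2 to compound 3 (0.41 log units; beyond the scatter), which the earlier compounds could not show. The other step is a 1.6-fold higher number from compound 1 to compound 3 (0.21 log units; within the scatter), so the 4-(methoxycarbonyl)phenyl group cannot be told apart from vinyl here, unlike 4-bromophenyl. No evidence is available to explain this change. On these data alone, only bromo and methoxycarbonyl are compared on this carbon, so the result for a carboxylic acid or an amine there stays open.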